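A few compounds are considered here, and "the series" means these few. Any claim that something is new, unique, unknown or untested is made for them only; others in the source may bear on it.

Measured so far:
Compound 1 `C#CCCCC[n+]1ccn(C(C)(C)C)c1/C=N/O`: 8.06
Compound 2 `C#CCCOC[n+]1ccn(C(C)(C)C)c1/C=N/O`: 7.84
Compound 3 `C#CCCOC[n+]1ccc(/C=N/O)cc1`: 8.18

In a physicochemical assay for acid dissociation, these three compounds sit close together. Compound 3 has the highest number of the three, within the scatter of compound 1 but beyond it from compound 2. For the measured compounds named here, the one change measured on a single core, (pent-4-yn-1-yl in place of (but-3-yn-1-yl)oxy on a saturated chain carbon bound to an aromatic nitrogen), gave a number 0.22 log units higher from compound 2 to compound 1 (within the scatter). Compound 4 `C#CCCCC[n+]1ccc(/C=N/O)cc1` carries the same change on the core of compound 3, (pent-4-yn-1-yl in place of (but-3-yn-1-yl)oxy on a saturated chain carbon bound to an aromatic nitrogen), at a place that reads the same word for word; the difference between the two cores is not broken down here. Going by the values given here, the step is expected to be small again, a number 0.22 log units higher from compound 3 to compound 4 (within the scatter), resting on a number 0.22 log units higher from compound 2 to compound 1 (within the scatter) as the only precedent. Compound 4 is therefore estimated at 8.4, between 8.1 and 8.7.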

Compound 4, acid dissociation constant: 8.36
Compound 4: middle estimate off by 0.04 log units, on the high side, and the stated range covers the measured number.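

In this assay pent-4-yn-1-yl in place of (but-3-yn-1-yl)oxy gave a number 0.18 log units higher from compound 3 to compound 4 (within the scatter) and, on the other core, a number 0.22 log units higher from compound 2 to compound 1 (within the scatter) as well. The change therefore carried from one core to the other with a step inside the scatter both times, which shows that it stayed small on these two cores but not that it has a real effect of a fixed size. Two pairs cannot show that it would carry to further cores, and no measurement offered here accounts for either step.

The compounds shown leave open how the number would respond to an amine, a carboxylic acid or a longer chain in place of pent-4-yn-1-yl.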